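The compounds below may be only part of what the source reports. "The series", "measured", "known", "first", "only" and "open" are said of these compounds alone.

Measured so far:

Compound 1 `COc1ccc(C2CC(c3ccccc3)=NN2c2ccccc2)cc1`, an assay for inhibition of cathepsin H (Capra hircus), using Lineweaver-Burk analysis; on this read-out higher numbers stand for weaker inhibition and lower numbers for stronger inhibition: 2120 nM
Compound 2 `Cc1ccc(C2CC(c3ccccc3)=NN2)cc1`, this assay: 8200 nM

Compound 2 gives the highest number of the two in this assay; compound 1 sits at a lower number, and the gap between the two lies beyond the scatter of repeated measurements. Within the data shown here, compound 1 differs from compound 2 in more than one place, so the two values together show only that compound 1 inhibits more strongly, not which change carries the difference.

Compound 3 `COc1ccc(C2CC(c3ccccc3)=NN2)cc1` is not yet measured. It carries methoxy in place of methyl on an aromatic carbon, and is otherwise the same as compound 2. Among the measured compounds shown here, no single-change step from a measured pair is available to calibrate this exchange, so only a small step is expected from compound 2 to compound 3, towards a somewhat lower number and barely beyond the scatter, a 1.6-fold lower number from compound 2 to compound 3 (0.21 log units; within the scatter). Compound 3 is expected to give about 5000 nM in this assay, within a range from 2000 nM to 12000 nM.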

Compound 3, inhibition constant: 9800 nM
Beside the measured number, compound 3's estimate is 2.0-fold (0.29 log units) below it, within the range that was stated.
By their numbers in this assay, from the lowest: compound 1; then compounds 2 and 3 (each within the scatter of the next).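

In this assay, methoxy in place of methyl on an aromatic carbon, para to a large group, leaves the read-out within the scatter (a 1.2-fold higher number from compound 2 to compound 3 (0.08 log units; within the scatter)), so this position shows no response to this exchange. Hydrogen in place of phenyl on the amine nitrogen in a ring gives the first single-change step at that nitrogen and lies beyond the scatter (a 4.6-fold higher number from compound 1 to compound 3 (0.66 log units; beyond the scatter)), with phenyl on the side of the lower number; the gap seen earlier between compound 1 and compound 2 therefore fits the change at the nitrogen rather than the one on the aromatic carbon. No measurement in hand bears on why either step has this size.

Still open, on these data alone, is whether the aromatic carbon would respond to a different kind of group, such as an amine or a carboxylic acid, since methyl and methoxy are the only two compared there. As far as these compounds go, it is also open whether the gain at the ring nitrogen is specific to phenyl or would also appear with benzyl or a longer chain.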